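Inverting one sugar ring stereocentre: lipophilicity expected unchanged

This account rests on a few compounds, and the source may have more. Where it says the series, first, only, none or still open, it means among the compounds named here.

Measured compounds in a physicochemical assay for lipophilicity, at pH 7.4; on this read-out lower numbers stand for lower lipophilicity and higher numbers for higher lipophilicity:
compound 1, `Cc1ccccc1OCC(O)COC(=O)CCC(=O)/C=C/OC[C@H]1OC(O)[C@H](O)[C@@H](O)[C@@H]1O`, gives 0.04
compound 2, `O=C(/C=C/OC[C@H]1OC(O)[C@H](O)[C@@H](O)[C@@H]1O)CCC(=O)OCC(O)COc1ccc(Cl)cc1`, gives 0.02

Compound 2 holds the lowest of the two numbers in this assay, with compound 1 nearest; the gap between them is within the scatter. Within the data shown here, the only measured step, a number 0.02 log units lower from compound 1 to compound 2 (within the scatter), is itself within the scatter and concerns the aryl group, not the sugar portion.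

Compound 3, `O=C(/C=C/OC[C@H]1OC(O)[C@@H](O)[C@@H](O)[C@@H]1O)CCC(=O)OCC(O)COc1ccc(Cl)cc1`, has not yet been measured. Its difference from compound 2 is the two compounds have the same atoms and bonds; at least one stereo element is drawn with a configuration in one of them and without one in the other: 1 of 7 stereo elements differ; a stereocentre at a saturated ring carbon is drawn R in compound 2 and S in compound 3. Among the measured compounds shown here, no measured step concerns a change of this kind; the one available step, a number 0.02 log units lower from compound 1 to compound 2 (within the scatter), bears on it only in showing that this series has so far given closely matched numbers. With nothing entering or leaving the molecule, compound 3 is expected to show no step beyond the scatter in this assay, that is, an expected step of no change at the digits printed from compound 2 to compound 3 (within the scatter). For compound 3 the estimate in this assay is therefore 0.02, expected to lie between -0.28 and 0.32.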

Compound 3, distribution coefficient: 0.07
For compound 3 the middle estimate is 0.05 log units below the measured one; the measured number falls inside the stated range.
By their numbers in this assay, from the lowest: compounds 2, 1 and 3 (each within the scatter of the next).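

In this assay, changing the configuration at a saturated ring carbon gave a number 0.05 log units higher from compound 2 to compound 3 (within the scatter), with the 4-chlorophenyl group and the rest of the structure held constant. Among these compounds, the earlier step from compound 1 to compound 2 concerned only the aryl group, so this is the first reading at this ring position, and it does not separate the two drawn forms. The comparison carries one limit, which applies to how the two structures are defined and so to what the step can be taken to represent: the fact that one of compounds 2 and 3 is drawn with a defined configuration and the other without, at the place where they differ

The compounds shown leave open whether a change of configuration at any of the other stereocentres would also stay within the scatter, and whether the same holds with the 2-methylphenyl group in place of 4-chlorophenyl. They also leave open whether replacing the group at this ring carbon with an amine or a carboxylic acid, rather than only changing its configuration, would give a step beyond the scatter in this assay.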